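Carbamate Replaces Ethyl on the Aromatic Oxygen

A few compounds are considered here, and "the series" means these few. Any claim that something is new, unique, unknown or untested is made for them only; others in the source may bear on it.

Measured compounds:
compound 1 `CCOc1cc(=O)n(CCCO)c2c1CC(CC=C(C)C)C(C)(C)C2` — 66.5%
compound 2 `CC(C)=CCC1Cc2c(OCCCNS(=O)(=O)c3ccc(Br)cc3)cc(=O)n(CCCO)c2CC1(C)C` — 19.5%

In a functional assay on PANC-1 cells (Homo sapiens) for inhibition, read by MTT assay, with a stated time of 24 h, tested at 10 uM (a higher number here means more inhibition at the concentration tested (going by the name of the read-out), a lower number less inhibition), compound 1 gives 66.5%, the highest of the two numbers measured. Compound 2 gives 19.5%. Going by the values given here, the single measured step is a number 47 percentage points lower from compound 1 to compound 2 (beyond the scatter), a large fall that comes with a bulky group placed on the saturated chain two bonds along from an oxygen on an aromatic ring.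

Compound 3 `CC(C)=CCC1Cc2c(OC(=O)Nc3ccc(F)c(F)c3)cc(=O)n(CCCO)c2CC1(C)C` differs from compound 1 as follows: (3,4-difluorophenyl)carbamoyl in place of ethyl on an oxygen on an aromatic ring. Among the compounds with values here, no measured step covers exactly this exchange, so the only guide is the step from compound 1 to compound 2, which also enlarges what sits at or near that aromatic oxygen. A drop is therefore expected, though a smaller one, since the new group is placed differently; the expected step is a number 26.5 percentage points lower from compound 1 to compound 3 (beyond the scatter). Compound 3 is estimated to give 40% in this assay, within a range from 12% to 65%.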

Compound 3, a percentage reported as inhibition, at one concentration (the size of the read-out at that concentration, not a potency): 76.7%
Estimate against measurement, compound 3: 36.7 percentage points below; the whole stated range lies below it.
By their numbers in this assay, from the lowest: compound 2; then compound 1; then compound 3.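

In this assay the exchange of ethyl for (3,4-difluorophenyl)carbamoyl on this aromatic oxygen gives a number 10.2 percentage points higher from compound 1 to compound 3 (beyond the scatter) and so shows that a much larger group can sit here with a modest gain in inhibition rather than a loss. Compound 2 alone, with a number 47 percentage points lower from compound 1 to compound 2 (beyond the scatter) for its change at the chain on the same oxygen, might have suggested that any large addition here is costly, but compound 3 goes against that reading, so what matters is which group is added and not simply that one is added. Nothing measured in this set explains why the two large groups part ways.

The compounds shown leave open whether the gain belongs to the carbamate link or to the difluorophenyl ring. An unsubstituted phenyl carbamate and a benzyl ether bearing the same 3,4-difluorophenyl ring would help to separate the two.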